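A few compounds are considered here, and "the series" means these few. Any claim that something is new, unique, unknown or untested is made for them only; others in the source may bear on it.

Compound 2, `O=C(O)CCc1ccc(S(=O)(=O)NNc2ccc(Br)cc2)cc1`, and compound 1, `CC(=O)Nc1ccc(S(=O)(=O)NNc2ccc(Br)cc2)cc1`, share one core and differ only in the group carried on one aromatic carbon. In an assay for inhibition of Indoleamine 2,3-dioxygenase 1 (Homo sapiens), read by spectrophotometry, with stated times of 1 h and 4 h (a lower number here means a stronger inhibitor, a higher number a weaker inhibitor), compound 1 gives 130 nM, and in the same assay compound 2 gives 141 nM. Among the two numbers shown, the one of compound 2 is not set apart: the step of a 1.1-fold higher number from compound 1 to compound 2 (0.04 log units; within the scatter) lies within the scatter, so the two compounds cannot be told apart by these values. Compound 3, `O=C(O)COc1ccc(S(=O)(=O)NNc2ccc(Br)cc2)cc1`, has not yet been measured. It differs from compound 2 in a single place: carboxymethoxy in place of 2-carboxyethyl on an aromatic carbon. Within the data shown here, only one measured step bears on this change, and it does so loosely, since it also swaps the group on that same aromatic carbon and produced no movement beyond the scatter. A further swap at this position is therefore expected to leave this assay about where it is, with the expected step being no change at the digits printed from compound 2 to compound 3 (within the scatter). Compound 3 is accordingly estimated at 141 nM, within a range from 70 nM to 280 nM.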

Compound 3, half-maximal inhibitory concentration: 125 nM
Compound 3: middle estimate off by 1.1-fold (0.05 log units), on the high side; the range from low to high includes it.
By their numbers in this assay, from the lowest: compounds 3, 1 and 2 (each within the scatter of the next).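

In this assay, carboxymethoxy in place of 2-carboxyethyl gives a 1.1-fold lower number from compound 2 to compound 3 (0.05 log units; within the scatter) and carboxymethoxy in place of acetamido gives a 1.0-fold lower number from compound 1 to compound 3 (0.02 log units; within the scatter) and so three different groups on this aromatic carbon now cannot be told apart by their numbers. The change from compound 2 to compound 3 is a narrow one, since the two groups have the same number of heavy atoms and the entering group has one carbon fewer, one oxygen more and one more hydrogen-bond acceptor, yet this exchange within the chain produces no movement beyond the scatter. Nothing shown here offers an explanation for how closely these three values agree.

As far as these compounds go, what an amine, a methyl ester of either acid or a longer chain ending in a carboxylic acid would do on this aromatic carbon remains open. From the compounds shown here alone, the bromine is also the same in all three compounds, so the effect of replacing it with chlorine or a methyl group on these numbers remains unknown as well.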